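Sulfonamide aryl variation in a bicyclic antiproliferative series

The source may report more compounds than this note shows. Statements on the series, on what has been measured and on what is new or still open speak of the compounds shown alone.

Measured compounds:
- compound 1 `CN(c1ccccc1)S(=O)(=O)C1CC2OC1C(c1ccc(NC(=O)CCCCCCC(=O)O)cc1)=C2c1ccc(O)cc1`: in a functional assay on DU-145 cells (Homo sapiens) for antiproliferative activity, read by MTT assay, with a stated time of 72 h (on this read-out lower numbers stand for stronger inhibition and higher numbers for weaker inhibition), compound 1 gives > 100000 nM, which is a limit of the assay and not a number.
- compound 2 `Cc1cccc(N(C)S(=O)(=O)C2CC3OC2C(c2ccc(NC(=O)CCCCCCC(=O)O)cc2)=C3c2ccc(O)cc2)c1`: in this assay compound 2 gives > 100000 nM, again a limit.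
- compound 3 `CN(c1ccccc1Cl)S(=O)(=O)C1CC2OC1C(c1ccc(NC(=O)CCCCCCC(=O)O)cc1)=C2c1ccc(O)cc1`: in this assay compound 3 gives 73500 nM.

For the measured compounds named here, compound 3 holds the only actual number in this assay; the other two values are limits, as the limit of > 100000 nM in this assay, at which 2 of the 3 values shown sit, records. The step of an at least 1.3-fold lower number from compound 1 to compound 3 (0.13 log units; that floor lies within the scatter) and the step of an at least 1.3-fold lower number from compound 2 to compound 3 (0.13 log units; that floor lies within the scatter) are each only floors, and both floors fall within the scatter, so no real gain for compound 3 can be read from them. The step that the two limits leave unreadable from compound 1 to compound 2 cannot be read at all.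

Compound 4 `CCN(c1ccccc1Br)S(=O)(=O)C1CC2OC1C(c1ccc(NC(=O)CCCCCCC(=O)O)cc1)=C2c1ccc(O)cc1` is the next member. Relative to compound 3 it carries (2-bromophenyl)(ethyl)amino in place of (2-chlorophenyl)(methyl)amino on a sulfonyl sulfur. The measured steps that touch the sulfonamide nitrogen substituent are those into compound 3, and they show at most movement within the scatter. Going by the values given here, no step tells how an ethyl on the nitrogen or a bromo on the ring would act. The expectation for compound 4 in this assay is therefore a value close to that of compound 3, with the step of a 1.1-fold lower number from compound 3 to compound 4 (0.02 log units; within the scatter) estimated to stay within the scatter, and a real chance that only a limit is reported. The estimate for compound 4 is 70000 nM, ranging from 30000 nM to 160000 nM.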

Compound 4, half-maximal inhibitory concentration: 95300 nM
For compound 4 the middle estimate is 1.4-fold (0.13 log units) below the measured one; the measured number falls inside the stated range.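

With a second actual number in the series, the exchange on the sulfonyl sulfur can be read directly: this assay shows a 1.3-fold higher number from compound 3 to compound 4 (0.11 log units; within the scatter). The ethyl and the bromo enter together, so this gives one joint reading for (2-bromophenyl)(ethyl)amino in place of (2-chlorophenyl)(methyl)amino and no separate reading for either group. Against the two compounds held at a limit of the assay, only floors can be read, an at least 1.0-fold lower number from compound 2 to compound 4 (0.02 log units; that floor lies within the scatter) and an at least 1.0-fold lower number from compound 1 to compound 4 (0.02 log units; that floor lies within the scatter), so no gain is shown, and the step between those two limits cannot be read.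

From the compounds shown here alone, whether any change at this position moves the read-out beyond the scatter stays open, with part of the set still recorded only as a limit: the limit of > 100000 nM in this assay, at which 2 of the 4 values shown sit. Going by these compounds, how a morpholine on the sulfonyl sulfur would read, or an amine in place of the carboxylic acid, also stays open, as does the separate contribution of the ethyl and the bromo.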